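From a Chlorophenyl to a Phenylethenyl on a Shared Core

A few compounds are considered here, and "the series" means these few. Any claim that something is new, unique, unknown or untested is made for them only; others in the source may bear on it.

Compound 1 `Cc1cc(O)c(C2=NN(c3ccc(S(N)(=O)=O)cc3)C(c3ccccc3O)C2)cc1Cl` and compound 2 `Cc1cc(O)c(C2=NN(c3ccc(S(N)(=O)=O)cc3)C(c3ccccc3Cl)C2)cc1Cl` share one core and differ in a single place. In a functional assay on LOX IMVI cells (Homo sapiens) for antiproliferative activity, with a stated time of 48 h (on this read-out higher numbers stand for weaker inhibition of growth and lower numbers for stronger inhibition of growth), compound 1 gives 1730 nM, and compound 2 gives 1780 nM. The step of a 1.0-fold higher number from compound 1 to compound 2 (0.01 log units; within the scatter) shows that this exchange leaves the number where it was, so compound 2 stands level with compound 1, the gap between them within the scatter. Compound 3 `Cc1cc(O)c(C2=NN(c3ccc(S(N)(=O)=O)cc3)C(/C=C/c3ccccc3)C2)cc1Cl` is not yet measured and differs from compound 2 as follows: 2-phenylethenyl in place of 2-chlorophenyl on a saturated ring carbon. Among the measured compounds shown here, no measured step touches this exchange directly; the only step seen at that ring carbon was within the scatter, which gives no sign that the site steers the number, and nothing is known about a phenylethenyl group here. Compound 3 is therefore expected to give 1800 nM in this assay, with a range from 600 nM to 5500 nM. The expected step of a 1.0-fold higher number from compound 2 to compound 3 (0.00 log units; within the scatter) is none beyond the scatter.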

Compound 3, concentration for 50% growth inhibition: 3940 nM
Beside the measured number, compound 3's estimate is 2.2-fold (0.34 log units) below it, within the range that was stated.
By their numbers in this assay, from the lowest: compounds 1 and 2 (each within the scatter of the next); then compound 3.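

The exchange at this saturated ring carbon moves the number in this assay (a 2.2-fold higher number from compound 2 to compound 3 (0.35 log units; beyond the scatter)), and the comparison with the hydroxy-bearing analogue moves it the same way (a 2.3-fold higher number from compound 1 to compound 3 (0.36 log units; beyond the scatter)). The site therefore does respond to what it carries, which the swap of hydroxy for chloro on the attached aromatic ring had not shown, though both steps are modest and both point toward weaker inhibition of growth. No measurement available here explains this shift.

From the compounds shown here alone, it stays open whether the double bond outside the aromatic ring or the longer reach of 2-phenylethenyl goes with the change. Going by these compounds, a saturated 2-phenylethyl group, a plain phenyl or an amine at this carbon could separate these readings, and whether any group here would give stronger inhibition of growth also remains unknown.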